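Lengthening the Alkyl Group on the Phenyl Ester

The source may hold more compounds than are shown below. What is called first, only, known or untested is meant among the compounds shown, and "the series" means these compounds.

Measured compounds in a functional assay on HT-29 cells (Homo sapiens) for cytotoxicity, read by sulforhodamine B assay, with a stated time of 48 h; a lower number here means a stronger inhibitor, a higher number a weaker inhibitor:
compound 1 `CCCc1ccccc1OS(=O)(=O)c1cccc(NC(=O)NCCCCl)c1` gives 14000 nM
compound 2 `O=C(NCCCCl)Nc1cccc(S(=O)(=O)Oc2ccc(O)cc2)c1` gives 51000 nM
compound 3 `Cc1ccccc1OS(=O)(=O)c1ccc(NC(=O)NCCCCl)cc1` gives 26000 nM

Compound 3 has the second highest of the three numbers, within the scatter of compound 1 and of compound 2 alike. Within the data shown here, the one step beyond the scatter, a 3.6-fold higher number from compound 1 to compound 2 (0.56 log units; beyond the scatter), swaps a whole phenyl ester for another and does not isolate the alkyl chain. Compound 4 `CCc1ccccc1OS(=O)(=O)c1ccc(NC(=O)NCCCCl)cc1` differs from compound 3 by methyl in place of hydrogen on a saturated chain carbon bound to an aromatic carbon. Among the measured compounds shown here, compound 1 bears a 2-propylphenyl where compound 3 bears a 2-methylphenyl, but the cores differ elsewhere too, so no single step links them; their values sit within the scatter of each other. The step from compound 3 to compound 4 is therefore expected to be a 1.3-fold lower number from compound 3 to compound 4 (0.11 log units; within the scatter). Compound 4 is estimated at 20000 nM, from 9000 nM to 45000 nM.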

Compound 4, half-maximal inhibitory concentration: 15000 nM
Compound 4: the middle estimate sits 1.3-fold (0.12 log units) above what was measured, within the range that was stated.
By their numbers in this assay, from the lowest: compounds 1, 4, 3 and 2 (each within the scatter of the next, the first and the last beyond it).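

Among these compounds, compound 3 and compound 4 give the first step here that touches only the alkyl group on the phenyl ester, and in this assay it reads (a 1.7-fold lower number from compound 3 to compound 4 (0.24 log units; within the scatter)). On this shared core, methyl in place of hydrogen on a saturated chain carbon bound to an aromatic carbon therefore leaves the two compounds indistinguishable. Nothing available explains this result.

Going by these compounds, whether a butyl chain or a carboxylic acid at this place on the core of compound 3 would give a step beyond the scatter remains open.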